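Swapping a Hydroxymethyl for a Methoxy on the Aryl Ring

The source may report more compounds than this note shows. Statements on the series, on what has been measured and on what is new or still open speak of the compounds shown alone.

Measured so far:
Compound 1 `Nc1nc(-c2ccccc2)nc2sc(-c3ccco3)nc12` gives 15 nM in an assay on CHO cells for displacement of a labelled ligand from adenosine receptor A3 (Homo sapiens), read by scintillation counting, with a stated time of 3 h; a lower number here means a stronger inhibitor, a higher number a weaker inhibitor.
Compound 2 `Nc1nc(-c2cccc(CO)c2)nc2sc(-c3ccco3)nc12` gives 0.9 nM in this assay.

Among the compounds with values here, compound 2 shows the lowest number of the two, and the one step measured, a 17-fold lower number from compound 1 to compound 2 (1.22 log units; beyond the scatter), is large. Compound 3 `COc1cccc(-c2nc(N)c3nc(-c4ccco4)sc3n2)c1` differs from compound 2 by methoxy in place of hydroxymethyl on an aromatic carbon. Within the data shown here, no measured step covers this exact change; only the step of a 17-fold lower number from compound 1 to compound 2 (1.22 log units; beyond the scatter) shows that a group at this place matters. Because a 17-fold lower number from compound 1 to compound 2 (1.22 log units; beyond the scatter) was large, compound 3 is expected to land between the two measured numbers, with a step of a 5.6-fold higher number from compound 2 to compound 3 (0.74 log units; beyond the scatter). Compound 3 is estimated at 5 nM, in the range 1.5 nM to 18 nM.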

Compound 3, inhibition constant: 4.9 nM
Compound 3: the middle estimate sits 1.0-fold (0.01 log units) above what was measured, and the stated range covers the measured number.
By their numbers in this assay, from the lowest: compound 2; then compound 3; then compound 1.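

Hydroxymethyl and methoxy have the same heavy atoms, but only hydroxymethyl carries a hydrogen-bond donor, and how those atoms are joined matters here (a 5.4-fold higher number from compound 2 to compound 3 (0.74 log units; beyond the scatter)). Even so, a group with no hydrogen-bond donor still improves on plain hydrogen (a 3.1-fold lower number from compound 1 to compound 3 (0.49 log units; beyond the scatter)). No evidence here accounts for either step.

On these data alone, what remains open is how an amine or a carboxylic acid would compare at this place. As far as these compounds go, a longer chain, such as ethoxy or hydroxyethyl, is equally open.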